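The compounds below may be only part of what the source reports. "The series", "measured", "known", "first", "only" and "open" are said of these compounds alone.

Compound 1, `O=S(=O)(Nc1ccc(-c2nc3ccccc3o2)cc1)c1ccccc1Cl`: in an assay on cells for inhibition of HSP60/HSP10 (Homo sapiens), with a stated time of 60 min (a higher number here means a weaker inhibitor, a lower number a stronger inhibitor), compound 1 reaches only a limit of the assay, > 100000 nM.
Compound 2, `O=S(=O)(Nc1ccc(-c2nc3ccccc3o2)cc1)c1cccc(O)c1`: in this assay compound 2 gives 62000 nM.
Compound 3, `O=S(=O)(Nc1ccc(-c2nc3ccccc3o2)cc1)c1cccs1`: in this assay compound 3 gives 63000 nM.

Compound 3 holds the higher of the two numbers in this assay; its nearest neighbour is compound 2, and the step of a 1.0-fold higher number from compound 2 to compound 3 (0.01 log units; within the scatter) lies within the scatter. The third value is a limit of the assay, (the limit of > 100000 nM in this assay, at which 1 of the 3 values shown sits), so compound 1 can be set against compound 3 only through the step of an at least 1.5-fold lower number from compound 1 to compound 3 (0.20 log units; that floor lies within the scatter).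

Compound 4, `C=Cc1ccc(S(=O)(=O)Nc2ccc(-c3nc4ccccc4o3)cc2)cc1`, is not yet measured. It differs from compound 3 at the sulfonyl sulfur: 4-vinylphenyl in place of thiophen-2-yl on a sulfonyl sulfur. Among the compounds with values here, two measured steps bear on this change, since both also exchange the group on the sulfonyl sulfur: an at least 1.5-fold lower number from compound 1 to compound 3 (0.20 log units; that floor lies within the scatter) and a 1.0-fold higher number from compound 2 to compound 3 (0.01 log units; within the scatter). Neither reaches beyond the scatter, so exchanging one aryl group for another at this position has, among these three compounds, left the number where it was. Compound 4 is therefore expected to sit close to compound 3, with the step of a 1.1-fold lower number from compound 3 to compound 4 (0.02 log units; within the scatter) meaning no change beyond the scatter. The estimate for compound 4 is 60000 nM, expected to fall between 20000 nM and 150000 nM.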

Compound 4, half-maximal inhibitory concentration: > 100000 nM
Compound 4 ended at the assay's limit (the forecaster's own chance of this, stated with the estimate: 30%); at least 1.6-fold (0.22 log units) between middle value and limit.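

Compound 4 is a limit of this assay, and it shows that exchanging one aryl group for another on the sulfonyl sulfur does not always return a readable number. That limit now holds for two compounds with different groups at this position: the limit of > 100000 nM in this assay, at which 2 of the 4 values shown sit. Set against the two measured compounds, 4-vinylphenyl gives an at least 1.5-fold higher number from compound 3 to compound 4 (0.20 log units; that floor lies within the scatter) and an at least 1.6-fold higher number from compound 2 to compound 4 (0.20 log units; that floor lies within the scatter), so both floors stay within the scatter and neither step alone shows a real loss, though the true gaps may be larger.

The step between compound 1 and compound 4 cannot be read, as both values are limits. Also open, going by these compounds, is whether an amine or a carboxylic acid on the phenyl ring at this position would move the number beyond the scatter of compound 2 and compound 3.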